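The source may hold more compounds than are shown below. What is called first, only, known or untested is meant among the compounds shown, and "the series" means these compounds.

Measured so far:
compound 1 `CCOC(=O)C1CCN(Cn2nc(Cc3ccc(SC)cc3)oc2=S)CC1`: 57.4%
compound 2 `CSc1ccc(Cc2nn(CN3CCN(c4cccc(Cl)c4)CC3)c(=S)o2)cc1`: 74.7%

In a functional assay on the whole organism (strain Wister albino) for inhibition, with Rattus norvegicus as the target, read by paw edema, with stated times of 30 min and 3 h, at a dose of 10 mg/kg by the oral route (on this read-out lower numbers stand for less inhibition and higher numbers for more inhibition at the one dose given (going by the name of the read-out)), compound 2 gives 74.7%. Among the compounds with values here, that is the highest of the two numbers known here. Within the data shown here, the only other number, from compound 1, stands lower by more than the usual scatter, so compound 2 is ahead of compound 1 in this assay by a gap that is real rather than noise. Compound 1 and compound 2 differ in more than one place, so their two values show a difference but do not isolate any single change.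

The next compound, compound 3 `CSc1ccc(Cc2nn(CN3CCN(c4ccc(F)cc4)CC3)c(=S)o2)cc1`, is built from compound 2 by one change: 4-fluorophenyl in place of 3-chlorophenyl on an amine nitrogen in a ring. Among the measured compounds shown here, no measured pair shows this exact change, so its effect has to be guessed. Both groups are small aromatic rings of the same size with one halogen each, so the expectation is a step in this assay of no more than modest size, if any, with a slight lean downward from the high mark of compound 2; a step of a number 6.7 percentage points lower from compound 2 to compound 3 (within the scatter) is expected. Compound 3 is estimated at 68%, with a range from 50% to 84%.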

Compound 3, a percentage reported as inhibition, in the whole organism at one dose (the size of the read-out at that dose, not a potency): 68.7%
Estimate against measurement, compound 3: 0.7 percentage points below; low and high end bracket the measured number.
By their numbers in this assay, from the lowest: compound 1; then compounds 3 and 2 (each within the scatter of the next).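

In this assay, placing 4-fluorophenyl where 3-chlorophenyl stood on the amine nitrogen in a ring gives a number 6 percentage points lower from compound 2 to compound 3 (within the scatter), so this pair cannot be told apart in this test. Within the data shown here, this is the first comparison here that isolates a single change, and it shows that this position accepts either of these two halogen-bearing phenyl groups without a step that stands clear of the usual spread of repeat measurements. The swap alters both the halogen and its place on the phenyl ring at once, and nothing available here explains why the two compounds read alike.

The compounds shown leave open whether the kind of halogen and its place on the ring matter separately, which a 4-chlorophenyl group at this position would help to settle. They also leave open whether a halogen or an aromatic ring is needed at all, a question that a plain phenyl group or a simple methyl on the same nitrogen could address in this assay.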